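The compounds below may be only part of what the source reports. "The series", "measured", "known", "first", "only" and "open" are said of these compounds alone.

Measured so far:
compound 1 `Cc1cccc(NC(=S)N/N=C\c2c[nH]c3ccccc23)c1` — > 100000 nM
compound 2 `CCCNC(=S)N/N=C\c1c[nH]c2ccccc12` — > 100000 nM

In an ADME assay on KB cells (Homo sapiens) for cytotoxicity, read by MTT assay, with a stated time of 44 h (a lower number here means a stronger inhibitor, a higher number a weaker inhibitor), compound 1 gives only a limit, > 100000 nM. Compound 2 in this assay likewise gives only a limit, > 100000 nM. Within the data shown here, both values sit at the limit of > 100000 nM in this assay, at which 2 of the 2 values shown sit, so the single step between them, a step that the two limits leave unreadable from compound 1 to compound 2, carries no readable size. Compound 3 `CC(C)CNC(=S)N/N=C\c1c[nH]c2ccccc12` differs from compound 2 by methyl in place of hydrogen on a saturated chain carbon bound to two saturated chain carbons. Among the measured compounds shown here, no measured step bears on this change with a readable size, so no direction beyond the scatter is expected. Compound 3 is thus expected to remain at the limit in this assay, estimated at 150000 nM (range 50000 nM to 500000 nM). The expected step is a step that the limit leaves unreadable from compound 2 to compound 3.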

Compound 3, half-maximal inhibitory concentration: > 100000 nM
Compound 3 was reported as a limit (the forecaster's own chance of this, stated with the estimate: 90%); the middle value lies beyond the limit too.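

Compound 1, compound 2 and compound 3 all sit at a limit in this assay, so no step among them can be read: the limit of > 100000 nM in this assay, at which 3 of the 3 values shown sit.

The compounds shown leave open whether any group on the amide-type nitrogen gives a readable value in this assay.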